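A few compounds are considered here, and "the series" means these few. Any claim that something is new, unique, unknown or untested is made for them only; others in the source may bear on it.

Among the measured compounds shown here, compound 1 `CC1(C)CNC(=O)c2sc(Nc3ccc(I)cc3Cl)c(C(=O)NCC[C@@H](O)CO)c2C1` and compound 2 `CC1(C)CNC(=O)c2sc(Nc3ccc(I)cc3F)c(C(=O)NOC[C@H](O)CO)c2C1` differ in more than one place, so no single-change step connects them. In a functional assay on HT-29 cells (Homo sapiens) for antiproliferative activity (on this read-out higher numbers stand for weaker inhibition and lower numbers for stronger inhibition), compound 1 gives 12100 nM, the higher of the two numbers recorded, while compound 2 gives 1580 nM, a gap beyond the usual scatter. Compound 3 `CC1(C)CNC(=O)c2sc(Nc3ccc(I)cc3Cl)c(C(=O)NC[C@@H](O)CO)c2C1` is compound 1 with 1,2-dihydroxyethyl in place of 2,3-dihydroxypropyl on a saturated chain carbon bound to an amide-type nitrogen. For the measured compounds named here, no measured pair isolates this change; the step of a 1.2-fold lower number from compound 1 to compound 3 (0.08 log units; within the scatter) is expected to be small, with no clear direction and possibly none beyond the scatter. Compound 3 is therefore estimated at 10000 nM, within a range from 3500 nM to 30000 nM.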

Compound 3, half-maximal inhibitory concentration: 710 nM
Beside the measured number, compound 3's estimate is 14-fold (1.15 log units) above it; the measured number lies below the stated range.
By their numbers in this assay, from the lowest: compound 3; then compound 2; then compound 1.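

At this position, on a saturated chain carbon bound to an amide-type nitrogen, this assay responds strongly to a small edit: 1,2-dihydroxyethyl in place of 2,3-dihydroxypropyl gives a 17-fold lower number from compound 1 to compound 3 (1.23 log units; beyond the scatter), although the hydrogen-bond donor and acceptor counts stay the same. The gain therefore follows the shorter chain, not a change in those counts. No supporting data bear on the reason for this step.

Still open, from the compounds shown here alone, is whether an amine or a carboxylic acid in place of the diol would keep this gain. Going by these compounds, the effect of inverting the defined stereocentre of 1,2-dihydroxyethyl also remains open.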